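The source may report more compounds than this note shows. Statements on the series, on what has been measured and on what is new or still open speak of the compounds shown alone.

Measured compounds:
compound 1 `COc1ccc(/C=C2\N=C(c3ccc(C)cc3)N(C(=O)c3nc4c(c(C)nn4-c4ccccc4)c(=O)[nH]3)NC2=O)cc1`: 36.8 nM
compound 2 `Cc1nn(-c2ccccc2)c2nc(C(=O)N3NC(=O)/C(=C/c4ccccc4)N=C3c3ccc(Cl)cc3)[nH]c(=O)c12`: 55 nM
compound 3 `Cc1nn(-c2ccccc2)c2nc(C(=O)N3NC(=O)/C(=C/c4ccc(Cl)cc4)N=C3c3ccc(Cl)cc3)[nH]c(=O)c12`: 19.3 nM

In an ADME assay on WI-38 cells (Homo sapiens) for cytotoxicity, read by MTT assay, with a stated time of 48 h (on this read-out higher numbers stand for weaker inhibition and lower numbers for stronger inhibition), compound 3 gives the lowest number of the three. Compound 1 sits within the scatter of it, while compound 2 lies beyond the scatter, as the step of a 2.8-fold lower number from compound 2 to compound 3 (0.45 log units; beyond the scatter) shows. Compound 4 `COc1ccc(/C=C2\N=C(c3ccc(Cl)cc3)N(C(=O)c3nc4c(c(C)nn4-c4ccccc4)c(=O)[nH]3)NC2=O)cc1` is not yet measured. The change from compound 3 is methoxy in place of chloro on an aromatic carbon. Among the compounds with values here, no measured step covers this exchange directly; the only step at the same position, a 2.8-fold lower number from compound 2 to compound 3 (0.45 log units; beyond the scatter), is modest. Compound 4 carries the same methoxy group as compound 1. Compound 1 gives 36.8 nM, while compound 3 with chloro at that position gives 19.3 nM; the two lie within the scatter of each other, and compound 1 differs from compound 4 elsewhere, so that pair is only a loose guide. The expected step of a 1.6-fold higher number from compound 3 to compound 4 (0.19 log units; within the scatter) is therefore small, with no confident direction beyond the scatter. Compound 4 is estimated at 30 nM in this assay, with a range of 14 nM to 65 nM.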

Compound 4, half-maximal inhibitory concentration: 25 nM
Estimate against measurement, compound 4: 1.2-fold (0.08 log units) above, within the range that was stated.
By their numbers in this assay, from the lowest: compounds 3, 4, 1 and 2 (each within the scatter of the next, the first and the last beyond it).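

In this assay, the exchange of 4-chlorophenyl for 4-methoxyphenyl gives a 1.3-fold higher number from compound 3 to compound 4 (0.11 log units; within the scatter), so this position does not separate chloro from methoxy, even with the hydrogen-bond acceptor that methoxy adds. Hydrogen at the same position does stand apart: a 2.2-fold lower number from compound 2 to compound 4 (0.34 log units; beyond the scatter) shows that methoxy, like chloro before it, gives a step beyond the scatter. At the other substituted aromatic ring, with methoxy held in place, a 1.5-fold lower number from compound 1 to compound 4 (0.17 log units; within the scatter) likewise leaves chloro and methyl unseparated.

No measurement available gives a reason for any of these steps. Open, going by these compounds, is whether the tolerance at this position extends past these two groups to an amine, a carboxylic acid or a longer alkoxy chain, and whether any of them would return the number to that of compound 2.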